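This account rests on a few compounds, and the source may have more. Where it says the series, first, only, none or still open, it means among the compounds named here.

Compound 1 `O=S(=O)(/C=C/c1ccc(Br)cc1)Cc1ccc(Nc2ncnc3ccccc23)cc1`: > 100000 nM, a limit.
Compound 2 `O=S(=O)(/C=C/c1ccc(F)cc1F)Cc1ccc(Nc2ncnc3ccccc23)cc1`: > 100000 nM, a limit.

In a functional assay on U-251 cells (Homo sapiens) (on this read-out lower numbers stand for stronger inhibition of growth and higher numbers for weaker inhibition of growth), compound 2 gives > 100000 nM, which is a limit and not a number. The record so far is the limit of > 100000 nM in this assay, at which 2 of the 2 values shown sit. Compound 3 `O=S(=O)(/C=C/c1ccc(F)cc1Cl)Cc1ccc(Nc2ncnc3ccccc23)cc1` differs from compound 2 at one place: chloro in place of fluoro on an aromatic carbon, ortho to a large group. Among the measured compounds shown here, the only measured step that bears on this is a step that the two limits leave unreadable from compound 1 to compound 2, so it gives no size to carry over. Compound 3 is therefore expected to stay near the same limit, with no change beyond the scatter in either direction. The expected step is a number no higher from compound 2 to compound 3 (the limit leaves the size open). Compound 3 is estimated at 100000 nM, within an expected range of 30000 nM to 300000 nM.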

Compound 3, concentration for 50% growth inhibition: 100000 nM
Beside the measured number, compound 3's estimate shows no gap at the digits printed; measured number inside the range.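

In this assay, among the compounds shown here, compound 3 gives 100000 nM and this is the first value shown that is a number and not a limit. As far as these compounds go, the record shows a number no higher from compound 2 to compound 3 (the limit leaves the size open) and a number no higher from compound 1 to compound 3 (the limit leaves the size open) and neither step can be read in size, so the size of the change from fluoro to chloro at this place remains unknown. The record remains a limit: the limit of > 100000 nM in this assay, at which 2 of the 3 values shown sit.

From the compounds shown here alone, what remains open is whether any group at this place would give a clearly lower number. A methoxy group or an amine there would test this, and neither is among the compounds shown.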